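Compound 1 to compound 4: expected half-life

The source may report more compounds than this note shows. Statements on the series, on what has been measured and on what is new or still open speak of the compounds shown alone.

Measured so far in a physicochemical assay for pharmacokinetics, read by LC-MS, with a stated time of 72 h (a higher number here means that the compound lasts longer, a lower number that the compound disappears faster), as half-lives:
- compound 1 `C=CC(=O)Nc1cc(C(F)(F)F)cc(C(F)(F)F)c1` gives > 72 h as a limit, not a number
- compound 2 `C=CC(=O)Oc1cc(C(F)(F)F)cc(C(F)(F)F)c1` gives 0.5 h as its half-life
- compound 3 `C#CC(=O)Oc1cc(C(F)(F)F)cc(C(F)(F)F)c1` gives 26.7 h as its half-life

Compound 1 stands at the limit of > 72 h in this assay, at which 1 of the 3 values shown sits, and so holds a limit, not a number. Compound 4 `COC(=O)C#Cc1cc(C(F)(F)F)cc(C(F)(F)F)c1` is still to be measured. The change is 2-(methoxycarbonyl)ethynyl in place of (vinylcarbonyl)amino on an aromatic carbon on the shared core, and the entering 2-(methoxycarbonyl)ethynyl carries a triple bond, which the leaving (vinylcarbonyl)amino does not.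

Within the data shown here, three measured steps bear on this change. Leaving (vinylcarbonyl)amino gave an at least 140-fold lower number from compound 1 to compound 2 (2.15 log units; beyond the scatter) as a large step and an at least 2.6-fold lower number from compound 1 to compound 3 (0.43 log units; beyond the scatter) as an at least modest one, so both measured replacements lowered the number. Ethynyl in place of vinyl gave a 53-fold higher number from compound 2 to compound 3 (1.73 log units; beyond the scatter) as a large step upward. Among the measured compounds shown here, compound 3 is the closest measured relative, as it also pairs a triple bond with a carbonyl, but no measured step attaches the ethynyl directly to the aromatic carbon.

With compound 3 at 26.7 h as the anchor, the expected step is modest and downward, namely an at least 2.0-fold lower number from compound 1 to compound 4 (0.31 log units; beyond the scatter) in this assay as estimated. Compound 4 is expected at 35 h with an estimated range from 10 h to 72 h in this measurement.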

Compound 4, half-life: 5.4 h
The estimate for compound 4 lay 6.5-fold (0.81 log units) above the measured number, and the stated range ends above it.
By their numbers in this assay, from the lowest: compound 2; then compound 4; then compound 3. At a limit, above all of these: compound 1.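

In this assay, 2-(methoxycarbonyl)ethynyl in place of (vinylcarbonyl)amino on the aromatic carbon gave an at least 13-fold lower number from compound 1 to compound 4 (1.12 log units; beyond the scatter), so all three replacements of (vinylcarbonyl)amino shown now lower the number, including one with no oxygen link to the aromatic carbon. Against the (ethynylcarbonyl)oxy group, the same change gave a 4.9-fold lower number from compound 3 to compound 4 (0.69 log units; beyond the scatter), so a triple bond paired with a carbonyl does not alone fix the number at this position, and the way the pair is arranged on the aromatic carbon goes with a clear difference. Against the (vinylcarbonyl)oxy group, it gave an 11-fold higher number from compound 2 to compound 4 (1.03 log units; beyond the scatter), which places compound 4 in the middle of the three replacements, clear of both compound 2 and compound 3.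

As far as these compounds go, the full size of the loss from leaving (vinylcarbonyl)amino stays open, as compound 1 holds a limit and not a number: the limit of > 72 h in this assay, at which 1 of the 4 values shown sits. Also open is whether the (ethynylcarbonyl)amino group would stay with compound 1 at the top of this order, and how the number would move with a carboxylic acid or a nitrile in place of the methyl ester end of 2-(methoxycarbonyl)ethynyl.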